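This account rests on a few compounds, and the source may have more. Where it says the series, first, only, none or still open, it means among the compounds named here.

In a functional assay on NCI-H1975 cells (Homo sapiens) for inhibition, read by MTT assay, with a stated time of 72 h (on this read-out lower numbers stand for stronger inhibition and higher numbers for weaker inhibition), three compounds with a common core have been measured. Compound 1 `FC(F)(F)c1ccc(CSc2nc(N3CCNCC3)cc(C(F)(F)F)n2)cc1` gives 6210 nM, compound 2 `CN1CCN(c2cc(C(F)(F)F)nc(SCc3ccc(C(F)(F)F)cc3)n2)CC1` gives 23900 nM, and compound 3 `FC(F)(F)c1ccc(CSc2nc(Sc3nnnn3-c3ccccc3)cc(C(F)(F)F)n2)cc1` gives 24300 nM. Compound 3 thus stands within the scatter of compound 2, and its number lies beyond the scatter from that of compound 1.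

Compound 4 `Cc1nnc(Sc2cc(C(F)(F)F)nc(SCc3ccc(C(F)(F)F)cc3)n2)s1` differs from compound 3 in one place, with 5-methyl-1,3,4-thiadiazol-2-yl in place of 1-phenyl-1H-tetrazol-5-yl on a sulfur. Within the data shown here, no measured step covers a change on this sulfur. Among the measured compounds shown here, the only step available, a 3.8-fold higher number from compound 1 to compound 2 (0.59 log units; beyond the scatter), is a modest one that swaps methyl for hydrogen on an amine nitrogen in a ring, so it offers a rough size for a single change and no direction for this one. On that slender basis, the starting point is compound 3 at 24300 nM, and compound 4 is expected to stay within the scatter of that value. The estimated change is a 1.4-fold lower number from compound 3 to compound 4 (0.13 log units; within the scatter). For compound 4 the expected value is 18000 nM, with an estimated range of 7000 nM to 45000 nM.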

Compound 4, half-maximal inhibitory concentration: 3060 nM
Compound 4: middle estimate off by 5.9-fold (0.77 log units), on the high side; the measured number lies below the stated range.
By their numbers in this assay, from the lowest: compound 4; then compound 1; then compounds 2 and 3 (each within the scatter of the next).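

In this assay, among these compounds, the first measured change on this sulfur moves the number beyond the scatter: 5-methyl-1,3,4-thiadiazol-2-yl in place of 1-phenyl-1H-tetrazol-5-yl gives a 7.9-fold lower number from compound 3 to compound 4 (0.90 log units; beyond the scatter) with fewer heavy atoms in the entering group. Attachment through sulfur therefore does not fix the number at this aromatic carbon, as (5-methyl-1,3,4-thiadiazol-2-yl)sulfanyl gives a 7.8-fold lower number from compound 2 to compound 4 (0.89 log units; beyond the scatter) in place of 4-methylpiperazin-1-yl and a 2.0-fold lower number from compound 1 to compound 4 (0.31 log units; beyond the scatter) in place of piperazin-1-yl. Nothing available explains why these steps take this direction or size.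

The compounds shown leave open whether the lower number follows the thiadiazole ring or the departure of the phenyl ring, a question that 1-methyl-1H-tetrazol-5-yl on the same sulfur would address. They also leave open what the methyl on the thiadiazole contributes, which hydrogen or an amine in its place would test.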